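Methoxy to dimethylamino on the core of compound 2

The source may report more compounds than this note shows. Statements on the series, on what has been measured and on what is new or still open speak of the compounds shown alone.

Measured compounds
Compound 1, `COc1ncnc2c1c(-c1ccoc1)cn2[C@@H]1O[C@H](CO)[C@@H](O)[C@H]1O`: 290 nM
Compound 2, `COc1ncnc2c1c(-c1cccs1)cn2[C@@H]1O[C@H](CO)[C@@H](O)[C@H]1O`: 13900 nM
Compound 3, `COc1ncnc2c1c(-c1ccccc1)cn2[C@@H]1O[C@H](CO)[C@@H](O)[C@H]1O`: > 20000 nM (a limit of the assay)

In a functional assay on HepG2 cells (Homo sapiens) for antiproliferative activity, read by XTT assay, with a stated time of 72 h (on this read-out higher numbers stand for weaker inhibition and lower numbers for stronger inhibition), compound 1 gives 290 nM and compound 2 gives 13900 nM. For compound 3 the value > 20000 nM is a limit of this assay and not a number. Among the two numbers shown, compound 2 stands highest, with the step of a 48-fold higher number from compound 1 to compound 2 (1.68 log units; beyond the scatter) separating it from compound 1. The step of an at least 68-fold higher number from compound 1 to compound 3 (1.83 log units; beyond the scatter) runs to the limit (the limit of > 20000 nM in this assay, at which 1 of the 3 values shown sits), and the step of an at least 1.4-fold higher number from compound 2 to compound 3 (0.15 log units; that floor lies within the scatter) is a floor only.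

Compound 4, `CN(C)c1ncnc2c1c(-c1cccs1)cn2[C@@H]1O[C@H](CO)[C@@H](O)[C@H]1O`, differs from compound 2 by one change: dimethylamino in place of methoxy on an aromatic carbon. For the measured compounds named here, none of the measured steps touches this position; all three exchange the aromatic ring on the other side of the shared core. Going by the values given here, there is therefore no measured step that bears on the methoxy-to-dimethylamino change, and no direction can be taken from the data. The expectation for this assay is a step within the scatter, a 1.0-fold higher number from compound 2 to compound 4 (0.00 log units; within the scatter), with a wide range to reflect the absence of a comparable step. Compound 4 is estimated at 14000 nM, with a range from 4000 nM to 40000 nM; a limit result is plausible.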

Compound 4, half-maximal inhibitory concentration: > 20000 nM
Compound 4 gave a limit, no number (the forecaster's own chance of this, stated with the estimate: 35%); middle value at least 1.4-fold (0.15 log units) away from the limit.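

In this assay compound 4 gives > 20000 nM, which is a limit of the assay and not a number. For the compounds shown here, this is the first change at the position next to the ring nitrogen rather than on the exchanged aromatic ring, and the step, an at least 1.4-fold higher number from compound 2 to compound 4 (0.15 log units; that floor lies within the scatter), is a floor only, so its true size cannot be read. On the thiophen-2-yl compounds, dimethylamino in place of methoxy brings no gain in inhibition, and this position now also leads to the upper end of the measurable range: the limit of > 20000 nM in this assay, at which 2 of the 4 values shown sit.

Going by these compounds, the effect of dimethylamino on the furan-3-yl side chain remains open, as a compound of that kind would start from the measurable value of compound 1, 290 nM, and could give a step of readable size. Also open, on these data alone, is how an unsubstituted amino group, a methylamino group or a plain methyl group would read at this position, and whether methoxy itself is needed there.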